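The source may report more compounds than this note shows. Statements on the series, on what has been measured and on what is new or still open speak of the compounds shown alone.

Measured so far in a functional assay on TM4 cells (Mus musculus) for cytotoxicity, read by MTT assay, with a stated time of 72 h; on this read-out higher numbers stand for weaker inhibition and lower numbers for stronger inhibition:
- compound 1 `Nc1nc(Nc2ccccc2)sc1C(=O)c1cccc(F)c1`: 5100 nM
- compound 2 `Nc1nc(Nc2ccc(S(N)(=O)=O)cc2)sc1C(=O)c1cccc(F)c1`: 4800 nM

Only these two compounds have been measured, and they cannot be told apart. Going by the values given here, the one step between them is a 1.1-fold lower number from compound 1 to compound 2 (0.03 log units; within the scatter), so adding the sulfamoyl group left the number within the ordinary scatter of this assay. Among the compounds with values here, compound 2, at 4800 nM, therefore stands level with its only neighbour.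

The next compound is compound 3 `Nc1nc(Nc2ccc(S(N)(=O)=O)cc2)sc1C(=O)c1ccccc1`. It differs from compound 2 at one place: hydrogen in place of fluoro on an aromatic carbon. Hydrogen takes the place of fluoro on an aromatic carbon, so the 3-fluorophenyl becomes a phenyl.

Within the data shown here, no measured step tests this change directly, since compound 1 and compound 2 both carry the fluoro. Among the measured compounds shown here, the step of a 1.1-fold lower number from compound 1 to compound 2 (0.03 log units; within the scatter) shows only that one change elsewhere on this scaffold made no visible difference, which is weak guidance. With nothing pointing either way, no shift beyond the scatter is expected. The estimated step is a 1.0-fold higher number from compound 2 to compound 3 (0.02 log units; within the scatter). For compound 3 the estimate is 5000 nM, with an expected range of 2400 nM to 10000 nM.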

Compound 3, half-maximal inhibitory concentration: 9100 nM
Compound 3: the middle estimate sits 1.8-fold (0.26 log units) below what was measured, and the stated range covers the measured number.
By their numbers in this assay, from the lowest: compounds 2, 1 and 3 (each within the scatter of the next).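

In this assay, going by these compounds alone, replacing the 3-fluorophenyl with a phenyl gives a 1.9-fold higher number from compound 2 to compound 3 (0.28 log units; within the scatter) and is the first direct test of this position, as compounds 1 and 2 both carry the fluoro and differ only on the other side of the molecule. Compound 2 and compound 3 therefore cannot be told apart, which means that the single fluorine atom on this aromatic carbon has no effect here that can be separated from the ordinary variation between repeated measurements. This is a finding about one small exchange on one scaffold, and no other information is available to explain the result.

Going by these compounds, whether this position tolerates every change remains open, as a methoxy group, a trifluoromethyl group or an amine on the same carbon could still move the number beyond the scatter. It is also unknown whether a fluoro on a different carbon of this ring, or a chlorine in the same place, would behave as the fluoro does here.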